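Permeability expected after swapping dichlorophenyl for dimethylphenyl

The compounds below may be only part of what the source reports. "The series", "measured", "known", "first", "only" and "open" are said of these compounds alone.

Compound 1 `Cc1oc(-c2c(Cl)cccc2Cl)nc1CN1CCC(C(=O)NCCCN2C[C@H](C)C[C@H](C)C2)CC1` has "not determined" (no result reported) in a physicochemical assay for permeability, using PAMPA (on this read-out higher numbers stand for higher permeability and lower numbers for lower permeability), so it stands nowhere among the numbers shown. Compound 2 `Cc1ccccc1-c1nc(CN2CCC(C(=O)NCCCN3CC4CCCC(C4)C3)CC2)c(C)o1` gives 331 10^-6 cm/s in this assay. Compound 3 `Cc1ccccc1-c1nc(CN2CCC(C(=O)N3CCN(C4CCN(C)CC4)CC3)CC2)c(C)o1` gives only < 3.2 10^-6 cm/s in this assay, which is a limit of the assay and not a number, namely (the limit of < 3.2 10^-6 cm/s in this assay, at which 1 of the 3 values shown sits). Compound 4 `Cc1cc(C)cc(-c2nc(CN3CCC(C(=O)NCCCN4C[C@H](C)C[C@H](C)C4)CC3)c(C)o2)c1` differs from compound 1 by 3,5-dimethylphenyl in place of 2,6-dichlorophenyl on an aromatic carbon. No measured step links any two of these compounds, so the size of the step from compound 1 to compound 4 in this assay cannot be read from the data, and none beyond the scatter is expected. Because compound 2 gives 331 10^-6 cm/s, compound 4 is expected to give 250 10^-6 cm/s, between 80 10^-6 cm/s and 600 10^-6 cm/s.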

Compound 4, apparent permeability: 864 10^-6 cm/s
Compound 4: middle estimate off by 3.5-fold (0.54 log units), on the low side; measured number above the stated range.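

Among these compounds, compound 1 has no number in this assay, so no step to compound 4 can be read. What the change from 2,6-dichlorophenyl to 3,5-dimethylphenyl does on its own stays open, and nothing shown accounts for the value of compound 4.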